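The source may report more compounds than this note shows. Statements on the series, on what has been measured and on what is new or still open speak of the compounds shown alone.

Series notes. For the measured compounds named here, of the three numbers so far in a toxicity assay on L02 cells (Homo sapiens) for cytotoxicity, read by MTT assay, with a stated time of 24 h (on this read-out higher numbers stand for lower toxicity in this test and lower numbers for higher toxicity in this test), compound 3 `CCCCS(=O)(=O)Oc1ccc(/C=C/C(=O)OCC(C)C)cc1OC` gives the lowest, at 63800 nM; compound 1 `CCCCS(=O)(=O)Oc1ccc(/C=C/C(=O)Nc2ccc(CC)cc2)cc1OC` gives 89000 nM and compound 2 `CCCCS(=O)(=O)Oc1ccc(/C=C/C(=O)OC)cc1OC` gives 208000 nM. The step of a 3.3-fold lower number from compound 2 to compound 3 (0.51 log units; beyond the scatter) lies beyond the scatter, whereas a 1.4-fold lower number from compound 1 to compound 3 (0.14 log units; within the scatter) lies within it, so compound 3 and compound 1 are not separated here. Compound 4 `CCCCS(=O)(=O)Oc1ccc(/C=C/C(=O)Nc2ccc(Cl)cc2)cc1OC` differs from compound 3 by (4-chlorophenyl)amino in place of isobutoxy on a carbonyl carbon. Going by the values given here, the only measured guide is the reverse of a 1.4-fold lower number from compound 1 to compound 3 (0.14 log units; within the scatter), which was within the scatter; no measured compound carries the (4-chlorophenyl)amino group. In this assay compound 4 is therefore expected close to compound 3, with an expected step of a 1.3-fold higher number from compound 3 to compound 4 (0.10 log units; within the scatter) that need not exceed the scatter. The estimate for compound 4 is 80000 nM, ranging from 35000 nM to 180000 nM.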

Compound 4, half-maximal cytotoxic concentration: 81200 nM
For compound 4 the middle estimate is 1.0-fold (0.01 log units) below the measured one; the range from low to high includes it.
By their numbers in this assay, from the lowest: compounds 3, 4 and 1 (each within the scatter of the next); then compound 2.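

On the carbonyl carbon, the (4-chlorophenyl)amino group cannot be told from the (4-ethylphenyl)amino group in this assay: chloro in place of ethyl on an aromatic carbon gives a 1.1-fold lower number from compound 1 to compound 4 (0.04 log units; within the scatter). Against isobutoxy it gives a 1.3-fold higher number from compound 3 to compound 4 (0.10 log units; within the scatter), also within the scatter, while against methoxy it gives a 2.6-fold lower number from compound 2 to compound 4 (0.41 log units; beyond the scatter), so of these four compounds only compound 2 stands apart. No available evidence bears on the reason for this pattern. Open, from the compounds shown here alone, is how a carboxylic acid or a piperidine amide on the carbonyl carbon would read.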